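Swapping a (methylsulfonyl)oxy group for fluorine

A few compounds are considered here, and "the series" means these few. Any claim that something is new, unique, unknown or untested is made for them only; others in the source may bear on it.

Three compounds share one core and differ only in the group on the oxygen, or in its place, on the benzene ring. In an assay for inhibition of Dihydrofolate reductase (Gallus gallus) (on this read-out higher numbers stand for weaker inhibition and lower numbers for stronger inhibition), compound 1 `Nc1ncc(Cc2ccccc2O)c(N)n1` gives 89100 nM, compound 2 `C=CCOc1ccccc1Cc1cnc(N)nc1N` gives 21400 nM, and compound 3 `CS(=O)(=O)Oc1ccccc1Cc1cnc(N)nc1N` gives 22900 nM. Compound 3 thus stands second highest of the three, close to compound 2 and well below compound 1. The measured steps of a 4.2-fold lower number from compound 1 to compound 2 (0.62 log units; beyond the scatter) and a 3.9-fold lower number from compound 1 to compound 3 (0.59 log units; beyond the scatter) show that replacing the bare hydroxyl hydrogen with either group helps to a modest extent, while a 1.1-fold higher number from compound 2 to compound 3 (0.03 log units; within the scatter) shows no difference between the two larger groups.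

Compound 4 `Nc1ncc(Cc2ccccc2F)c(N)n1` is the next step: fluoro in place of (methylsulfonyl)oxy on an aromatic carbon. Within the data shown here, no measured step covers this change. Fluorine, like the hydroxyl of compound 1, is a single small substituent, and compound 1 gives 89100 nM; the larger groups of compound 2 and compound 3 gave lower numbers. Compound 4 is therefore expected to land between those results, a step of a 2.2-fold higher number from compound 3 to compound 4 (0.34 log units; beyond the scatter), with an estimate of 50000 nM in this assay, ranging from 15000 nM to 160000 nM.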

Compound 4, inhibition constant: 43700 nM
Compound 4: the middle estimate sits 1.1-fold (0.06 log units) above what was measured; the measured number falls inside the stated range.
By their numbers in this assay, from the lowest: compounds 2, 3 and 4 (each within the scatter of the next, the first and the last beyond it); then compound 1.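

In this assay fluoro, with a single heavy atom, cannot be told apart from the five-heavy-atom (methylsulfonyl)oxy group, as a 1.9-fold higher number from compound 3 to compound 4 (0.28 log units; within the scatter) shows, so at this position the size of the group alone does not set the number. The step of a 2.0-fold higher number from compound 2 to compound 4 (0.31 log units; beyond the scatter) is small but does separate fluoro from allyloxy, even though allyloxy and (methylsulfonyl)oxy match each other. With a 2.0-fold lower number from compound 1 to compound 4 (0.31 log units; beyond the scatter) as its measure, fluoro also improves on hydroxy, so a gain over compound 1 does not require a large group.

Nothing available explains why these groups give these numbers. As far as these compounds go, whether chloro, an amine or a longer chain such as butoxy on this aromatic carbon would go further remains open.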